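A 4-chlorophenyl group added to compound 2

The source may report more compounds than this note shows. Statements on the series, on what has been measured and on what is new or still open speak of the compounds shown alone.

Compound 1 `CCc1nc2cc(Cl)ccn2c1C(=O)NCc1ccc(-c2ccc(C)cc2)cc1` at 0.423 h
Compound 2 `CCc1nc2cc(Cl)ccn2c1C(=O)NCc1ccc(N2CCCCC2)cc1` at 0.22 h

In an ADME assay (liver) for metabolic stability, with Liver microsome (Homo sapiens) as the target, using microsomes (a lower number here means that the compound disappears faster, a higher number that the compound lasts longer), compound 2 stands at 0.22 h and lies within the scatter of compound 1. Compound 3 `CCc1nc2cc(Cl)ccn2c1C(=O)NCc1ccc(N2CCC(c3ccc(Cl)cc3)CC2)cc1` differs from compound 2 by 4-chlorophenyl in place of hydrogen on a saturated ring carbon in one place, with 4-chlorophenyl in place of hydrogen on a saturated ring carbon. Going by the values given here, only one measured step bears on this, and only loosely. It is a 1.9-fold lower number from compound 1 to compound 2 (0.28 log units; within the scatter) for piperidin-1-yl in place of 4-methylphenyl on an aromatic carbon. Among the compounds with values here, no measured compound carries a group on that saturated ring carbon, so the numbers point in no direction. No step beyond the scatter is therefore expected in this assay for this change. The estimate amounts to a 1.1-fold lower number from compound 2 to compound 3 (0.04 log units; within the scatter) as the expected step. For compound 3 the expected half-life is 0.2 h with an estimated range from 0.09 h to 0.45 h in this measurement.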

Compound 3, half-life: 1.12 h
Compound 3: the middle estimate sits 5.6-fold (0.75 log units) below what was measured; measured number outside the range, above it.
By their numbers in this assay, from the lowest: compounds 2 and 1 (each within the scatter of the next); then compound 3.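

In this assay, the saturated ring carbon, three ring bonds from the ring nitrogen, proves to be a place where a change can move the number beyond the scatter: 4-chlorophenyl in place of hydrogen gives a 5.1-fold higher number from compound 2 to compound 3 (0.71 log units; beyond the scatter) at this position. The earlier step, a 1.9-fold lower number from compound 1 to compound 2 (0.28 log units; within the scatter), stayed within the scatter and concerned a different place, an aromatic carbon, so it gave no reading of this ring carbon. Nothing available accounts for the rise, and this single step shows only its direction and size at this position.

The compounds shown leave open whether the whole ring or its chlorine carries the step, as plain phenyl or 4-fluorophenyl on the same carbon would tell. They also leave open how a small group there, such as methyl or a hydroxyl, would behave.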